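The compounds below may be only part of what the source reports. "The series", "measured", "known", "first", "only" and "open" are said of these compounds alone.

Measured so far in a functional assay on A549 cells (Homo sapiens) for cytotoxicity, read by sulforhodamine B assay, with a stated time of 48 h; on this read-out lower numbers stand for stronger inhibition and higher numbers for weaker inhibition:
Compound 1 `COc1ccc(/C=C/C(=O)c2ccc(N)c(-c3ccc(F)cc3)c2)cc1OC` gives 8630 nM.
Compound 2 `COc1ccc(-c2cc(C(=O)/C=C/c3cc(OC)c(OC)c(OC)c3)ccc2N)cc1OC` gives 4620 nM.

Compound 2 has the lowest of the two numbers; its nearest neighbour is compound 1, whose number is higher by an amount that stays within the usual scatter, so the two cannot be ranked against each other. Among the measured compounds shown here, no pair of measured compounds differs in a single place, so no isolated step is available as a guide.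

Compound 3 `COc1cc(/C=C/C(=O)c2ccc(N)c(-c3ccc(F)cc3)c2)cc(OC)c1OC` is not yet measured. It differs from compound 2 in one place: 4-fluorophenyl in place of 3,4-dimethoxyphenyl on an aromatic carbon. Both measured values sit close together, and the change is a swap of one aryl group for another of the same ring size. Compound 3 is therefore expected to stay near compound 2, with the step of a 1.3-fold higher number from compound 2 to compound 3 (0.11 log units; within the scatter) estimated as small, leaning toward a slightly higher number, and not clearly beyond the scatter. The estimate for compound 3 is 6000 nM, with a range from 2500 nM to 15000 nM.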

Compound 3, half-maximal inhibitory concentration: 6070 nM
For compound 3 the middle estimate is 1.0-fold (0.01 log units) below the measured one; the measured number falls inside the stated range.
By their numbers in this assay, from the lowest: compounds 2, 3 and 1 (each within the scatter of the next).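

In this assay, 4-fluorophenyl in place of 3,4-dimethoxyphenyl on an aromatic carbon ortho to an amino group gives a 1.3-fold higher number from compound 2 to compound 3 (0.12 log units; within the scatter), so this first single-place comparison at this position shows that the aryl swap leaves no readable mark on the number. Methoxy in place of hydrogen on an aromatic carbon gives a 1.4-fold lower number from compound 1 to compound 3 (0.15 log units; within the scatter) and is likewise not separable from repeat measurement, so neither single change can be ranked. Nothing measured here bears on why these numbers stay together. The compounds shown leave open whether a morpholine or a carboxylic acid in place of the 4-fluorophenyl would move the number beyond the scatter. They also leave open what an acetamide in place of the amino group would do.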